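Compound 3: replacing the cyclopropyl imidazole

This account rests on a few compounds, and the source may have more. Where it says the series, first, only, none or still open, it means among the compounds named here.

In an ADME assay on microsomes from liver (Homo sapiens) for metabolic stability (on this read-out lower numbers stand for slow clearance and higher numbers for fast clearance), the values are as follows:
- compound 1 `Cc1csc(C(=O)N[C@H]2CN(S(=O)(=O)c3ccccc3)C[C@@H]2C(=O)N[C@H]2CCCNC2)n1` gives 9.1 mL.min-1.g-1
- compound 2 `O=C(N[C@H]1CN(S(=O)(=O)c2ccccc2)C[C@@H]1C(=O)N[C@H]1CCCNC1)c1cn(C2CC2)cn1` gives < 3 mL.min-1.g-1

Compound 2 reads < 3 mL.min-1.g-1 as a limit and not a number. The change to compound 3 `O=C(N[C@H]1CN(S(=O)(=O)c2ccccc2)C[C@@H]1C(=O)N[C@H]1CCCNC1)c1cc(-c2ccccc2)on1` is 5-phenyl-1,2-oxazol-3-yl in place of 1-cyclopropyl-1H-imidazol-4-yl on a carbonyl carbon and it falls on the carbonyl carbon. For the measured compounds named here, the only measured step at this place is an at least 3.0-fold lower number from compound 1 to compound 2 (0.48 log units; beyond the scatter) and compound 3 gives up the group that this step brought in. An upward step beyond the scatter is therefore expected in this assay, of about that size or somewhat larger. The expected step is an at least 4.6-fold higher number from compound 2 to compound 3 (0.66 log units; beyond the scatter) as estimated here. The estimate for compound 3 is 14 mL.min-1.g-1, expected within 5 mL.min-1.g-1 to 40 mL.min-1.g-1.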

Compound 3, intrinsic clearance in microsomes: < 3 mL.min-1.g-1
Compound 3 was reported as a limit; the forecaster's own chance of this, stated with the estimate: 10%; middle value at least 4.6-fold (0.66 log units) from the limit.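

In this assay compound 3 gives < 3 mL.min-1.g-1, a limit and not a number. 5-Phenyl-1,2-oxazol-3-yl in place of 4-methyl-1,3-thiazol-2-yl also gives an at least 3.0-fold lower number from compound 1 to compound 3 (0.48 log units; beyond the scatter), so the low reading at this carbonyl carbon is not tied to 1-cyclopropyl-1H-imidazol-4-yl. The steps between compound 2 and compound 3 cannot be read, and neither group can be ranked against the other: the limit of < 3 mL.min-1.g-1 in this assay, at which 2 of the 3 values shown sit.

From the compounds shown here alone, how far either compound lies under the limit stays open. So does whether a group carrying an amine or a carboxylic acid on this carbonyl carbon would stay at the limit or read nearer compound 1.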